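The source may hold more compounds than are shown below. What is called first, only, known or untested is meant among the compounds shown, and "the series" means these compounds.

Working notes on the thiourea series sharing the core of compound 1 `CNC(=O)c1ccc(Oc2cccc(NC(=S)Nc3ccc(F)c(C(F)(F)F)c3)c2)nc1`. Three members have numbers in a functional assay on HCT-116 cells (Homo sapiens) for antiproliferative activity, read by MTT assay; on this read-out higher numbers stand for weaker inhibition and lower numbers for stronger inhibition. Compound 1 gives 19000 nM. Compound 2 `CNC(=O)c1ccc(Oc2cccc(NC(=S)Nc3ccc(C)c(C)c3)c2)nc1` gives 48200 nM, and compound 3 `CNC(=O)c1ccc(Oc2cccc(NC(=S)Nc3ccc(Cl)cc3Cl)c2)nc1` gives 20900 nM. Compound 3 thus stands second highest of the three: compound 2 is the only one separated from it beyond the scatter, while compound 1 sits within the scatter of it. Among the compounds with values here, the one step that can be read here is a 2.3-fold lower number from compound 2 to compound 3 (0.36 log units; beyond the scatter), a modest change for swapping the ring on the thiourea nitrogen.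

Compound 4 `CNC(=O)c1ccc(Oc2cccc(NC(=S)Nc3ccc(F)c(Cl)c3)c2)nc1` has not yet been tested. It differs from compound 3 by 3-chloro-4-fluorophenyl in place of 2,4-dichlorophenyl on an amide-type nitrogen. Within the data shown here, the only comparable step, the swap of one ring for another on the same nitrogen, gave a modest move, and the whole set spans little more than that. A step of about the same size or none beyond the scatter is therefore expected, with no firm direction. The expected step is a 1.0-fold lower number from compound 3 to compound 4 (0.02 log units; within the scatter). For compound 4 the estimate in this assay is 20000 nM, with a range from 8000 nM to 50000 nM.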

Compound 4, half-maximal inhibitory concentration: 25400 nM
Estimate against measurement, compound 4: 1.3-fold (0.10 log units) below; the range from low to high includes it.
By their numbers in this assay, from the lowest: compounds 1, 3, 4 and 2 (each within the scatter of the next, the first and the last beyond it).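

In this assay the ring on the amide-type nitrogen takes 3-chloro-4-fluorophenyl in place of 2,4-dichlorophenyl with no readable shift (a 1.2-fold higher number from compound 3 to compound 4 (0.08 log units; within the scatter)), and chloro in place of trifluoromethyl on an aromatic carbon likewise stays within the scatter (a 1.3-fold higher number from compound 1 to compound 4 (0.13 log units; within the scatter)). Replacing 3,4-dimethylphenyl with this ring also stays within the scatter (a 1.9-fold lower number from compound 2 to compound 4 (0.28 log units; within the scatter)), whereas 2,4-dichlorophenyl in the same place went beyond it (a 2.3-fold lower number from compound 2 to compound 3 (0.36 log units; beyond the scatter)), so compound 2 no longer stands clearly apart from every halogen-bearing member. No measurement shown here accounts for these values.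

Going by these compounds, what an amine, a carboxylic acid or a methoxy group on this ring would do remains open. Also open, on these data alone, is how a carbonyl in place of the thiocarbonyl would read on these cells.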